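The compounds below may be only part of what the source reports. "The series", "measured", "known", "first", "only" and "open" are said of these compounds alone.

Measured so far in a functional assay on thoracic aorta for inhibition of Voltage-gated L-type calcium channel (Rattus norvegicus); a higher number here means a weaker inhibitor, a lower number a stronger inhibitor:
- compound 1, `CC1=NC(C)=C(C(=O)O)C(c2ccc([N+](=O)[O-])cc2)/C1=C(\O)OC/C=C/c1ccccc1`, gives 1600 nM
- compound 2, `COC(=O)c1cccc(C2C(C(=O)O)=C(C)N=C(C)/C2=C(/O)OC/C=C/c2ccccc2)c1`, gives 4400 nM
- compound 3, `CC1=NC(C)=C(C(=O)O)C(c2cccc(C)c2)/C1=C(\O)OC/C=C/c1ccccc1`, gives 76 nM

Compound 3 stands lowest of the three in this assay; its nearest neighbour is compound 1, and the step of a 21-fold lower number from compound 1 to compound 3 (1.32 log units; beyond the scatter) is large, while the step of a 58-fold lower number from compound 2 to compound 3 (1.76 log units; beyond the scatter) is larger still. Both steps exchange the whole aryl group on the saturated ring carbon, so they speak to the weight of that group without isolating any single substituent.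

Compound 4, `CC1=NC(C)=C(C(=O)O)C(c2cccc(F)c2)/C1=C(\O)OC/C=C/c1ccccc1`, differs from compound 3 by one exchange: fluoro in place of methyl on an aromatic carbon. Going by the values given here, no measured pair swaps methyl for fluoro, so the measured steps bear only indirectly, by showing how strongly the aryl substitution pattern moves the number. The change keeps a single small group in the same place on the ring and the result is expected to stay in the neighbourhood of compound 3, with a modest drift towards a higher number. The estimated step of a 2.0-fold higher number from compound 3 to compound 4 (0.30 log units; within the scatter) is therefore expected to be small. For compound 4 the estimate in this assay is 150 nM, with a range from 50 nM to 500 nM.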

Compound 4, half-maximal inhibitory concentration: 20 nM
Beside the measured number, compound 4's estimate is 7.5-fold (0.88 log units) above it; measured number below the stated range.
By their numbers in this assay, from the lowest: compound 4; then compound 3; then compound 1; then compound 2.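

In this assay the exchange of methyl for fluoro gives a 3.8-fold lower number from compound 3 to compound 4 (0.58 log units; beyond the scatter) and so moves the number beyond the scatter, although one heavy atom replaces one heavy atom at the same place and no hydrogen-bond donor, acceptor or net charge enters. The fluoro compound also widens the spread among the aryl groups, with a 220-fold lower number from compound 2 to compound 4 (2.34 log units; beyond the scatter) for the exchange against methoxycarbonyl and an 80-fold lower number from compound 1 to compound 4 (1.90 log units; beyond the scatter) for the exchange against 4-nitrophenyl. Nothing available accounts for the lower number with fluoro.

The compounds shown leave open whether chloro, hydroxy or an amine at this place would follow fluoro or methyl. They also leave open how fluoro would read on another carbon of the same ring.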